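Removing One Methoxy Group: Expected Effect on Cell Toxicity

The source may hold more compounds than are shown below. What is called first, only, known or untested is meant among the compounds shown, and "the series" means these compounds.

Compound 1 `COc1ccc(-c2cc(/C=C/C(=O)c3ccc(N)cc3)[nH]n2)cc1`: 87%
Compound 2 `COc1cc(-c2cc(/C=C/C(=O)c3ccc(N)cc3)[nH]n2)cc(OC)c1OC`: 93%

In a functional assay on Malme-3M cells (Homo sapiens) for cytotoxicity, read by sulforhodamine B assay, with a stated time of 48 h, tested at 1 uM (on this read-out higher numbers stand for a weaker effect at the one concentration tested and lower numbers for a stronger effect), compound 2 gives 93%, the highest of the two numbers. Its nearest neighbour, compound 1, gives 87% in this assay, and that difference lies within the usual scatter, so the two compounds cannot be ordered; both numbers stand for a weak effect at the one concentration tested. Among the compounds with values here, no two measured compounds differ in a single place, so no measured step is available as a guide.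

Compound 3 `COc1ccc(-c2cc(/C=C/C(=O)c3ccc(N)cc3)[nH]n2)cc1OC` has not yet been measured. It differs from compound 2 in one place: hydrogen in place of methoxy on an aromatic carbon. Since compound 1 and compound 2 sit so close together, the step from compound 2 to compound 3 is expected to be a number 3 percentage points lower from compound 2 to compound 3 (within the scatter), that is, nothing beyond the scatter. Compound 3 is therefore expected to give about 90% in this assay, most likely between 80% and 99%.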

Compound 3, a percentage reported as activity, at one concentration (the size of the read-out at that concentration, not a potency): 114%
Beside the measured number, compound 3's estimate is 24 percentage points below it; the whole stated range lies below it.
By their numbers in this assay, from the lowest: compounds 1 and 2 (each within the scatter of the next); then compound 3.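

Hydrogen in place of methoxy on this aromatic carbon gives a number 21 percentage points higher from compound 2 to compound 3 (beyond the scatter) in this assay, which stands for a weaker effect, so this position does respond to the change. Methoxy in place of hydrogen, starting from compound 1, gives a number 27 percentage points higher from compound 1 to compound 3 (beyond the scatter), so compound 3 stands apart from both neighbours and the read-out does not simply follow the number of methoxy groups on this ring. Nothing at hand explains why the two steps run this way.

The compounds shown leave open whether a hydroxyl group, a fluorine atom or an ethoxy group on this carbon would read like hydrogen or like methoxy. They also leave open whether the gap would hold at other concentrations, since only one was tested.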